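The source may report more compounds than this note shows. Statements on the series, on what has been measured and on what is new or still open speak of the compounds shown alone.

Working notes on the series. Compound 3 `Cc1nc(N)sc1CCCN/C(N)=N/C(=O)NCc1ccccc1` gives 28.8 nM in a functional assay on membranes from Sf9 cells for agonist activity at histamine H2 receptor (Homo sapiens), read by scintillation counting and GTPgammaS binding, with a stated time of 90 min; on this read-out higher numbers stand for an effect only at larger amounts of compound and lower numbers for an effect already at smaller amounts. Compound 2 `CCCCCCNC(=O)/N=C(\N)NCCCc1sc(N)nc1C` gives 38.9 nM in this assay; the move a 1.4-fold higher number from compound 3 to compound 2 (0.13 log units; within the scatter) corresponds to the change (pentyl in place of phenyl on a saturated chain carbon bound to an amide-type nitrogen). Compound 1 `N/C(=N\C(=O)NCc1ccccc1)NC1CCc2nc(N)sc2C1` carries a different core; in this assay compound 1 gives 214 nM, the highest number among the three measured, and the difference between the two cores is not broken down here. Going by the values given here, compound 4 `CCCCCCNC(=O)/N=C(\N)NC1CCc2nc(N)sc2C1` has not yet been measured; its relation to compound 1 is pentyl in place of phenyl on a saturated chain carbon bound to an amide-type nitrogen, the same change as the one between compound 3 and compound 2, at the same place. Because the earlier step of a 1.4-fold higher number from compound 3 to compound 2 (0.13 log units; within the scatter) stayed within the scatter, for compound 4 the expected step is a 1.3-fold higher number from compound 1 to compound 4 (0.12 log units; within the scatter), resting on that single precedent and on the starting point of compound 1. The expectation rests on one pair only, with a different core, so a larger deviation cannot be excluded. Compound 4 is estimated at 280 nM in this assay, with an expected range from 120 nM to 650 nM.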

Compound 4, half-maximal effective concentration: 148 nM
Estimate against measurement, compound 4: 1.9-fold (0.28 log units) above; low and high end bracket the measured number.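

On the core of compound 1, pentyl in place of phenyl gives a 1.4-fold lower number from compound 1 to compound 4 (0.16 log units; within the scatter) in this assay. Set beside the same change on the other core, the two steps show no difference that can be told apart from the scatter: the same change on two cores in this assay, a 1.4-fold higher number (0.13 log units; within the scatter) from compound 3 to compound 2 and a 1.4-fold lower number (0.16 log units; within the scatter) from compound 1 to compound 4, 2.0-fold (0.29 log units) apart, within the scatter of two such steps. This shows that, on these two cores, the exchange of phenyl for pentyl leaves the number within the scatter in both cases; it does not show a rule for the series, since it rests on one pair per core, and the opposite printed directions of the two steps cannot be read as a real reversal, nor can the two steps test whether a change with a clear effect would carry over from one core to another.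

Still open, on these data alone, is whether a longer chain, or a chain ending in an amine or a carboxylic acid, in place of pentyl would behave alike on both cores. Also open, as far as these compounds go, is how a substituted phenyl, such as a fluorophenyl, would compare on the two cores.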